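Compound 4: a 3-Methoxyphenyl Replaces the 2-Bromophenyl

The source may report more compounds than this note shows. Statements on the series, on what has been measured and on what is new or still open speak of the compounds shown alone.

The series shares one core, seen in compound 1 `O=C(Nc1cc(-c2ccccc2)nn1-c1ccccc1)c1ccc(Cl)c(Cl)c1`, compound 2 `O=C(Nc1cc(-c2ccccc2)nn1-c1ccccc1F)c1ccccc1` and compound 3 `O=C(Nc1cc(-c2ccccc2)nn1-c1ccccc1Br)c1ccccc1`. In a functional assay on cells for positive allosteric modulation of metabotropic glutamate receptor 5 (Rattus norvegicus), read by calcium flux (on this read-out lower numbers stand for an effect already at smaller amounts and higher numbers for an effect only at larger amounts of compound), compound 1 gives 13 nM, compound 2 gives 104 nM and compound 3 gives 200 nM. Compound 3 stands highest of the three, nearest to compound 2 and furthest from compound 1, which carries a different amide part and so offers no single-change comparison.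

Compound 4 `COc1cccc(-n2nc(-c3ccccc3)cc2NC(=O)c2ccccc2)c1` is not yet measured. It differs from compound 3 by 3-methoxyphenyl in place of 2-bromophenyl on an aromatic nitrogen. Within the data shown here, the only measured step on that same ring, a 1.9-fold higher number from compound 2 to compound 3 (0.28 log units; within the scatter), exchanges one halogen for another and stays within the scatter; no measured step exchanges a halogen for a methoxy group or moves a substituent on that ring, so the evidence bears on this change only loosely. Given that one change on this ring did little, the author expects compound 4 to show at most a small step, a 1.3-fold lower number from compound 3 to compound 4 (0.12 log units; within the scatter), and estimates 150 nM in this assay, with a range from 40 nM to 600 nM.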

Compound 4, half-maximal effective concentration: 570 nM
The estimate for compound 4 lay 3.8-fold (0.58 log units) below the measured number, and the stated range covers the measured number.
By their numbers in this assay, from the lowest: compound 1; then compounds 2 and 3 (each within the scatter of the next); then compound 4.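

In this assay, the aryl group on the aromatic nitrogen now shows a step beyond the scatter: replacing 2-bromophenyl with 3-methoxyphenyl gives a 2.9-fold higher number from compound 3 to compound 4 (0.45 log units; beyond the scatter), and replacing 2-fluorophenyl with 3-methoxyphenyl gives a 5.5-fold higher number from compound 2 to compound 4 (0.74 log units; beyond the scatter), whereas the exchange of one halogen for the other gave only a 1.9-fold higher number from compound 2 to compound 3 (0.28 log units; within the scatter). Both new steps run towards a higher number, so this position is not indifferent to every change, although each step alters the substituent and its place on the ring together. Nothing available here explains the rise in the number.

From the compounds shown here alone, whether the higher number goes with the methoxy group itself or with where it sits on the ring remains open. Also open, going by these compounds, is how the series would respond to an amine or a carboxylic acid on that phenyl ring.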